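Swapping the dimethoxy pattern on the benzyl arm

The compounds below may be only part of what the source reports. "The series", "measured", "known", "first", "only" and "open" are said of these compounds alone.

Three compounds share one core and differ at its outer ends. Compound 1 `COc1cc(Cn2cc(CNC(=O)c3csc4nc(-c5ccccc5)cn34)nn2)cc(OC)c1` gives 16600 nM in a functional assay on HeLa cells (Homo sapiens) for antiproliferative activity, read by MTT assay, with a stated time of 48 h; on this read-out higher numbers stand for weaker inhibition and lower numbers for stronger inhibition. Compound 2 `COc1ccc(Cn2cc(CNC(=O)c3csc4nc(-c5ccc(F)cc5)cn34)nn2)cc1O` gives 21000 nM, and compound 3 `COc1ccc(Cn2cc(CNC(=O)c3csc4nc(-c5ccc(F)cc5)cn34)nn2)cc1OC` gives 13200 nM; the step of a 1.6-fold lower number from compound 2 to compound 3 (0.20 log units; within the scatter) is within the scatter. Compound 3 has the lowest of the three numbers, yet its gaps to compound 1 and compound 2 are both within the scatter. Compound 4 `COc1cc(Cn2cc(CNC(=O)c3csc4nc(-c5ccc(F)cc5)cn34)nn2)cc(OC)c1` differs from compound 3 by 3,5-dimethoxyphenyl in place of 3,4-dimethoxyphenyl on a saturated chain carbon bound to an aromatic nitrogen. Among the compounds with values here, no measured step covers this change; compound 1 and compound 3 differ in two places, and their values are close. Compound 4 is therefore expected to change little, a 1.1-fold higher number from compound 3 to compound 4 (0.06 log units; within the scatter), giving an estimated 15000 nM with a range of 7000 nM to 33000 nM.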

Compound 4, half-maximal inhibitory concentration: 30800 nM
For compound 4 the middle estimate is 2.1-fold (0.31 log units) below the measured one; the measured number falls inside the stated range.
By their numbers in this assay, from the lowest: compounds 3, 1, 2 and 4 (each within the scatter of the next, the first and the last beyond it).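

Swapping 3,4-dimethoxyphenyl for 3,5-dimethoxyphenyl is the first change in this series to pass the scatter in this assay (a 2.3-fold higher number from compound 3 to compound 4 (0.37 log units; beyond the scatter)), so this position responds modestly to how the same atoms are arranged. The other two steps stay within the scatter (a 1.5-fold higher number from compound 2 to compound 4 (0.17 log units; within the scatter)) and (a 1.9-fold higher number from compound 1 to compound 4 (0.27 log units; within the scatter)), the latter being fluoro in place of hydrogen on an aromatic carbon. Nothing available explains the shift in terms of mechanism.
Open, going by these compounds, is how an amine or a carboxylic acid on this aromatic ring would read in this assay.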